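The source may hold more compounds than are shown below. What is called first, only, known or untested is meant among the compounds shown, and "the series" means these compounds.

Readings in an ADME assay on HEK293 cells (Homo sapiens) for cytotoxicity, read by MTT assay, with a stated time of 24 h (on this read-out lower numbers stand for stronger inhibition and higher numbers for weaker inhibition), for the measured members of the series:

compound 1 `Cc1cc(O)c(C(=O)/C=C/c2ccccc2Cl)c(-c2ccc(Cl)cc2)c1C(=O)/C=C/c1ccccc1Cl` gives 30000 nM
compound 2 `Cc1cc(O)c(C(=O)/C=C/c2ccc(Cl)cc2)c(-c2ccc(Cl)cc2)c1C(=O)/C=C/c1ccc(Cl)cc1` gives "not active" (no number reported)
compound 3 `Cc1cc(O)c(C(=O)/C=C/c2ccc(Cl)cc2)c(-c2ccc(Br)cc2)c1C(=O)/C=C/c1ccc(Cl)cc1` gives 25000 nM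

Compound 1 holds the highest of the two numbers; its nearest neighbour, compound 3, sits within the scatter of it, so the two cannot be ordered. Compound 2 returned no number in this assay.

Compound 4 `Cc1cc(O)c(C(=O)/C=C/c2ccccc2Cl)c(-c2ccccc2)c1C(=O)/C=C/c1ccccc1Cl` differs from compound 1 by hydrogen in place of chloro on an aromatic carbon. Within the data shown here, no measured pair tests this change, so nothing on hand shows its size. The expectation from compound 1 to compound 4 is a step of a 1.2-fold higher number from compound 1 to compound 4 (0.07 log units; within the scatter), that is, nothing clearly beyond the scatter. Compound 4 is therefore estimated at 35000 nM in this assay, with a likely range from 12000 nM to 100000 nM.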

Compound 4, half-maximal inhibitory concentration: "not active" (no number reported)
For compound 4 the study gives words and no number; no gap can be computed for the estimate.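

In this assay, among these compounds, compound 4 gives words and no number, so no step from compound 1 to compound 4 can be read. No evidence on hand bears on this result. The compounds shown leave open what the change from 4-chlorophenyl to phenyl does to the reading.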